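Trading a Sulfamoyl Group for a Nitrile

A few compounds are considered here, and "the series" means these few. Any claim that something is new, unique, unknown or untested is made for them only; others in the source may bear on it.

Compound 3 `CC(C)(N)CC(=O)N[C@@H]1CCc2ccccc2N(Cc2ccc(-c3ccccc3S(=O)(=O)NC(C)(C)C)cc2)C1=O` carries a (tert-butyl)sulfamoyl group on an aromatic carbon of the shared core. In a functional assay (Pituitary gland cell) with Rattus norvegicus as the target (a lower number here means that less compound is needed, a higher number that more compound is needed for the effect), compound 3 gives 4 uM, the highest number among the three measured compounds. Compound 1 `CC(O)Cn1nnc(-c2ccccc2-c2ccc(CN3C(=O)[C@H](NC(=O)CC(C)(C)N)CCc4ccccc43)cc2)n1` gives 0.05 uM, and compound 2 `Cn1nnnc1-c1ccccc1-c1ccc(CN2C(=O)[C@H](NC(=O)CC(C)(C)N)CCc3ccccc32)cc1` gives 0.5 uM. The two measured steps that lead to compound 3 both change the group on that same aromatic carbon: an 80-fold higher number from compound 1 to compound 3 (1.90 log units; beyond the scatter) and an 8.0-fold higher number from compound 2 to compound 3 (0.90 log units; beyond the scatter). Between the two tetrazole-bearing compounds themselves, a 10-fold higher number from compound 1 to compound 2 (1.00 log units; beyond the scatter).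

Compound 4 `CC(C)(N)CC(=O)N[C@@H]1CCc2ccccc2N(Cc2ccc(-c3ccccc3C#N)cc2)C1=O` differs from compound 3 in one place: cyano in place of (tert-butyl)sulfamoyl on an aromatic carbon. Among the compounds with values here, no measured step replaces the (tert-butyl)sulfamoyl group with anything other than a tetrazole, so the steps at hand show only that changes at this aromatic carbon can move the number by a lot, not which way a cyano group will move it. Both measured steps into compound 3 raised the number, so leaving the sulfamoyl group behind could plausibly lower it, yet a cyano group is much smaller than either tetrazole and shares little with them beyond a single hydrogen-bond acceptor. A step of a 1.3-fold lower number from compound 3 to compound 4 (0.12 log units; within the scatter) is therefore expected, with wide uncertainty. Compound 4 is estimated at 3 uM, within a range from 0.6 uM to 15 uM.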

Compound 4, concentration for half-maximal effect: 5 uM
Beside the measured number, compound 4's estimate is 1.7-fold (0.22 log units) below it, and the stated range covers the measured number.
By their numbers in this assay, from the lowest: compound 1; then compound 2; then compounds 3 and 4 (each within the scatter of the next).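

In this assay, replacing the (tert-butyl)sulfamoyl group, 8 heavy atoms with a hydrogen-bond donor, by a cyano group of 2 heavy atoms with none gives a 1.3-fold higher number from compound 3 to compound 4 (0.10 log units; within the scatter) and leaves the two compounds indistinguishable here, so this large difference in the group on the aromatic carbon has no readable effect on the number. The tetrazole compounds remain clearly separate from the cyano compound, with a 10-fold higher number from compound 2 to compound 4 (1.00 log units; beyond the scatter) and a 100-fold higher number from compound 1 to compound 4 (2.00 log units; beyond the scatter) as the two steps. Before, only the sulfamoyl group stood apart from the tetrazoles; now two unrelated non-tetrazole groups sit at the same level, and among these four compounds the lower numbers belong only to the two tetrazoles. Nothing in the available data explains these differences.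

The compounds shown leave open whether an unsubstituted tetrazole or a carboxylic acid on this aromatic carbon would reach the level of the tetrazole compounds. They also leave open whether the gain of compound 1 depends on the hydroxyl of its 2-hydroxypropyl chain, which a plain propyl chain on the tetrazole would test.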